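A 1H-Pyrazol-4-yl for a Pyridin-3-yl: Starting from Three Flat Results

The compounds below may be only part of what the source reports. "The series", "measured", "known", "first", "only" and "open" are said of these compounds alone.

Three compounds have so far been measured in an assay on CHO cells for displacement of a labelled ligand from adenosine receptor A3 (Homo sapiens), read by scintillation counting, tested at 10 uM; on this read-out higher numbers stand for more inhibition at the one concentration tested (going by the name of the read-out) and lower numbers for less inhibition:

Compound 1, `Nc1sc(-c2ccccc2)c(-c2ccccc2)c1C(=O)c1ccc(Cl)cc1`, gives 1%.
Compound 2, `CC(C)(C)Cc1c(-c2cccnc2)sc(N)c1C(=O)c1ccc(Cl)cc1`, gives 1%.
Compound 3, `CC(C)(C)Cc1c(Br)sc(N)c1C(=O)c1ccc(Cl)c(Cl)c1`, gives 1%.

Compound 2 stands level with compounds 1 and 3 at the digits shown. Its nearest neighbour on the numbers is compound 1, with no change at the digits shown, and its furthest is compound 3, again with no change at the digits shown; both gaps lie within the scatter. Within the data shown here, none of the three pairs differs in a single place, so no step between measured compounds is available as a yardstick.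

The compound that follows is compound 4, `CC(C)(C)Cc1c(-c2cn[nH]c2)sc(N)c1C(=O)c1ccc(Cl)cc1`. It differs from compound 2 in one place: 1H-pyrazol-4-yl in place of pyridin-3-yl on an aromatic carbon. The 1H-pyrazol-4-yl sits next to the ring sulfur and next to the ring atom that bears a neopentyl group.

Since the three measured compounds are all level, any guess for compound 4 can rest only on that flat picture. Compound 4 is expected to give 2% in this assay, with a range from 0% to 10%. The step this estimate implies, a number 1 percentage points higher from compound 2 to compound 4 (within the scatter), is expected to stay within the scatter, in no particular direction.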

Compound 4, a percentage reported as inhibition, at one concentration (the size of the read-out at that concentration, not a potency): 1%
Compound 4: the middle estimate sits 1 percentage points above what was measured; low and high end bracket the measured number.
By their numbers in this assay, from the lowest: compounds 1, 2, 3 and 4 (each within the scatter of the next).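

Among these compounds, the first single-place step, 1H-pyrazol-4-yl in place of pyridin-3-yl on the aromatic carbon next to the ring sulfur, shows in this assay no change at the digits printed from compound 2 to compound 4 (within the scatter). The earlier compounds shown here could only be set side by side across several differences, whereas this pair shows that one specific exchange at this position leaves the read-out where it was. That exchange replaces a six-membered aromatic ring with 1 hetero atom and 0 hydrogen-bond donors by a five-membered aromatic ring with 2 hetero atoms and 1 hydrogen-bond donor, and the number does not register the difference; nothing measured here offers an explanation for that.

From the compounds shown here alone, with these two aryl groups level, it remains open whether any group on this carbon can move the number at all, for example a carboxylic acid, a dimethylaminomethyl group or a longer chain such as n-butyl. Going by these compounds, it is equally open whether a change elsewhere would do so, such as an acetamide in place of the amino group or a cyclohexylmethyl group in place of the neopentyl group.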